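This account rests on a few compounds, and the source may have more. Where it says the series, first, only, none or still open, it means among the compounds named here.

Of the compounds shown here, three from one series have been measured in a functional assay on A549 cells (Homo sapiens) for antiproliferative activity, read by MTT assay, with a stated time of 72 h; on this read-out higher numbers stand for weaker inhibition and lower numbers for stronger inhibition. Compound 1, `O=C1COc2ccc(-c3cnc(Cl)c(NS(=O)(=O)c4ccc(F)cc4)c3)cc2N1C1CCCCC1`, gives 37900 nM in this assay. Compound 2, `Cc1ccc(N2C(=O)COc3ccc(-c4cnc(Cl)c(NS(=O)(=O)c5ccc(F)cc5)c4)cc32)cc1`, gives 30900 nM in this assay. The two differ in one place, (4-methylphenyl in place of cyclohexyl on an amide-type nitrogen in a ring), and the step this change made is a 1.2-fold lower number from compound 1 to compound 2 (0.09 log units; within the scatter). Compound 3, `O=C1COc2ccc(-c3cccc(NS(=O)(=O)c4ccc(F)cc4)c3)cc2N1C1CCCCC1`, gives 14500 nM in this assay, the lowest of the three numbers; its nearest neighbour is compound 2, whose number is higher by a margin beyond the scatter, and compound 1 lies further still. How the core of compound 3 differs from that of compound 1 is not broken down here.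

Compound 4, `Cc1ccc(N2C(=O)COc3ccc(-c4cccc(NS(=O)(=O)c5ccc(F)cc5)c4)cc32)cc1`, has not yet been measured in this assay. It stands to compound 3 as compound 2 stands to compound 1: the difference is 4-methylphenyl in place of cyclohexyl on an amide-type nitrogen in a ring, and since the place is described in the same words for both pairs, this is the same change. Going by the values given here, the only guide to its effect is the step from compound 1 to compound 2, which stayed within the scatter. Compound 4 is therefore expected to lie close to compound 3, with an estimated step of a 1.2-fold lower number from compound 3 to compound 4 (0.08 log units; within the scatter), resting on the comparable step a 1.2-fold lower number from compound 1 to compound 2 (0.09 log units; within the scatter). On that basis compound 4 is estimated to give about 12000 nM in this assay, with a range from 5000 nM to 30000 nM.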

Compound 4, half-maximal inhibitory concentration: > 40000 nM
Compound 4 gave a limit, no number; the forecaster's own chance of this, stated with the estimate: 10%; middle value at least 3.3-fold (0.52 log units) away from the limit.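

On the core of compound 3, 4-methylphenyl in place of cyclohexyl on an amide-type nitrogen in a ring gave an at least 2.7-fold higher number from compound 3 to compound 4 (0.44 log units; beyond the scatter) in this assay, whereas on the core of compound 1 the same change gave a 1.2-fold lower number from compound 1 to compound 2 (0.09 log units; within the scatter). The change therefore did not carry over from one core to the other with the same effect, and the step seen on one core would not have served as a reliable guide to the step on the other: the same change on two cores in this assay, a 1.2-fold lower number (0.09 log units; within the scatter) from compound 1 to compound 2 and an at least 2.7-fold higher number (0.44 log units; beyond the scatter) from compound 3 to compound 4, at least 3.3-fold (0.52 log units) apart, beyond the scatter of two such steps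
From the compounds shown here alone, for compound 4, the reading of > 40000 nM is a limit of the assay and not a number, so the full size of its step stays unknown, and these two pairs neither explain the difference between the cores nor tell how the change would behave on a third core.

The compounds shown leave open whether the difference follows from the aromatic ring or from its methyl group, which a plain phenyl group on the same nitrogen on both cores could separate. They also leave open how a group such as an amine or a carboxylic acid, carried on a short chain at that nitrogen, would behave on either core.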